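A Further Hydroxy on Compound 1

The source may hold more compounds than are shown below. What is called first, only, known or untested is meant among the compounds shown, and "the series" means these compounds.

In a functional assay on HeLa cells (Homo sapiens) for antiproliferative activity, read by MTT assay, with a stated time of 48 h (a higher number here means a weaker inhibitor, a lower number a stronger inhibitor), compound 1 (`Oc1ccc2c(c1)CCc1ccc(O)c(c1)Oc1ccc(cc1)CCc1cccc(O)c1O2`) gives 15900 nM. Among the measured compounds shown here, the only other measured compound, compound 2 (`Oc1cc2c(cc1O)Oc1c(O)cccc1CCc1ccc(cc1)Oc1cc(ccc1O)CC2`), gives 10400 nM, so the two values lie within the scatter of each other and compound 1 cannot be separated from its one neighbour. Compound 3 (`Oc1ccc2c(c1)CCc1ccc(O)c(c1)Oc1ccc(cc1O)CCc1cccc(O)c1O2`) has yet to be measured. It differs from compound 1 by a single change, hydroxy in place of hydrogen on an aromatic carbon of a six-membered aromatic ring of carbon only, ortho to a fused ring and meta to a fused ring.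

For the measured compounds named here, one measured step bears on this change. It is also hydroxy in place of hydrogen on an aromatic carbon, though not at the same carbon: a 1.5-fold lower number from compound 1 to compound 2 (0.18 log units; within the scatter). Resting on that single small step, no change beyond the scatter and no particular direction is expected in this assay. The expected step is small, a 1.3-fold lower number from compound 1 to compound 3 (0.12 log units; within the scatter). For compound 3 the estimated value is 12000 nM, with an expected range from 5500 nM to 26000 nM.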

Compound 3, half-maximal inhibitory concentration: 26800 nM
For compound 3 the middle estimate is 2.2-fold (0.35 log units) below the measured one; measured number outside the range, above it.
By their numbers in this assay, from the lowest: compounds 2, 1 and 3 (each within the scatter of the next, the first and the last beyond it).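

In this assay, hydroxy in place of hydrogen at this carbon, ortho to a fused ring and meta to a fused ring, gives a 1.7-fold higher number from compound 1 to compound 3 (0.23 log units; within the scatter), so the step cannot be told apart from repeat-measurement noise and the core of compound 1 accepts a hydroxy here without a measurable change. The earlier step, a 1.5-fold lower number from compound 1 to compound 2 (0.18 log units; within the scatter), came from a different carbon and said nothing directly about this one; the same change has now been read at two carbons, and both steps stay within the scatter, although two steps cannot establish a pattern across the core. No measured information is available to account for the step at this position.

The compounds shown leave open whether any replacement at this carbon could move the antiproliferative reading beyond the scatter, since a methoxy, an amine or a carboxylic acid there would each be a different test from a hydroxy. They also leave open whether the same small step would appear with hydroxy at other aromatic carbons of the core.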